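The source may report more compounds than this note shows. Statements on the series, on what has been measured and on what is new or still open speak of the compounds shown alone.

Measured compounds:
Compound 1, `N=C(N)NCCC[C@H](NC(=O)[C@@H](CC1CCCCC1)NCC(=O)O)C(=O)NCc1ccc(C(=N)N)cc1`, 100 nM in an assay on isolated protein for inhibition of vitamin K-dependent protein C (Homo sapiens); on this read-out higher numbers stand for weaker inhibition and lower numbers for stronger inhibition.
Compound 2, `N=C(N)NCCC[C@H](NC(=O)[C@@H](CC1CCCCC1)NCCC(=O)O)C(=O)NCc1ccc(C(=N)N)cc1`, 800 nM.

For the measured compounds named here, on these two numbers compound 1 stands lowest; the one step available, an 8.0-fold higher number from compound 1 to compound 2 (0.90 log units; beyond the scatter), concerns the acid-bearing chain on the amine nitrogen, a place left untouched in the step now considered. Compound 3, `N=C(N)c1ccc(CNC(=O)[C@@H](NC(=O)[C@@H](CC2CCCCC2)NCC(=O)O)C2CCNCC2)cc1`, differs from compound 1 by a group of 6 heavy atoms (5 carbon, 1 nitrogen; one six-membered non-aromatic ring with 1 hetero atom) in place of a group of 7 heavy atoms (4 carbon, 3 nitrogen; no ring), on a saturated chain carbon bound to an amide-type nitrogen and a carbonyl carbon. Going by the values given here, no measured pair speaks to this change, so the step from compound 1 to compound 2 cannot be carried over; the size of the effect in this assay is open, and the expectation is kept near the value of compound 1 with a wide range. For compound 3 the estimate in this assay is 200 nM, between 30 nM and 1500 nM. This estimate means an expected step of a 2.0-fold higher number from compound 1 to compound 3 (0.30 log units; within the scatter).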

Compound 3, inhibition constant: 900 nM
Beside the measured number, compound 3's estimate is 4.5-fold (0.65 log units) below it, within the range that was stated.
By their numbers in this assay, from the lowest: compound 1; then compounds 2 and 3 (each within the scatter of the next).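

For the compounds shown here, at the saturated chain carbon bound to an amide-type nitrogen and a carbonyl carbon, the earlier compounds carried the same group of 7 heavy atoms, so they gave no reading of this position. In this assay, piperidin-4-yl in place of that group gives a 9.0-fold higher number from compound 1 to compound 3 (0.95 log units; beyond the scatter), which shows that the position is not indifferent to this change on the core of compound 1. Nothing available explains the size or direction of this step. 

The change alters the ring count, the nitrogen count and the hydrogen-bond donor count together, and the compounds shown do not separate these features. Going by these compounds, it also remains open how a primary amine on an aminobutyl chain would read at this position, and whether piperidin-4-yl would give a similar step alongside the longer acid-bearing chain of compound 2.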